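The source may hold more compounds than are shown below. What is called first, only, known or untested is meant among the compounds shown, and "the series" means these compounds.

Measured so far, in a functional assay on SK-BR-3 cells (Homo sapiens) for antiproliferative activity; on this read-out higher numbers stand for weaker inhibition and lower numbers for stronger inhibition:

Compound 1 `COc1cccc(Oc2ccc3cc(NC(=O)c4ccc(O)c(CC=C(C)C)c4)c(=O)oc3c2C)c1` gives 33100 nM.
Compound 2 `CC(C)=CCc1cc(C(=O)Nc2cc3ccc(Oc4ccc(C(C)(C)C)cc4)c(C)c3oc2=O)ccc1O` gives 68300 nM.
Compound 3 `COc1cccc(Oc2ccc3cc(NC(=O)c4ccc(OC)c(-c5cccc(OC)c5)c4)c(=O)oc3c2C)c1` gives only a limit of the assay, > 100000 nM.

Compound 1 and compound 2 share one core and differ in a single place: 4-(tert-butyl)phenyl in place of 3-methoxyphenyl on an oxygen on an aromatic ring. This change gave a 2.1-fold higher number from compound 1 to compound 2 (0.31 log units; beyond the scatter), so the number rose and inhibition became somewhat weaker.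

Compound 3 rests on a different core, and the difference between the two cores is not broken down here. Compound 3 sits at the limit of > 100000 nM in this assay, at which 1 of the 3 values shown sits, so for it the assay reports a limit rather than a number.

Compound 4 `COc1cccc(-c2cc(C(=O)Nc3cc4ccc(Oc5ccc(C(C)(C)C)cc5)c(C)c4oc3=O)ccc2OC)c1` is the partner of compound 3 in the same change: 4-(tert-butyl)phenyl in place of 3-methoxyphenyl on an oxygen on an aromatic ring. The place of the change reads the same as for compound 1 and compound 2, so this is the same change, now made on the core of compound 3.

In this assay a step of the same size is expected, a step that the limit leaves unreadable from compound 3 to compound 4, since the same change between compound 1 and compound 2 gave a 2.1-fold higher number from compound 1 to compound 2 (0.31 log units; beyond the scatter). Because compound 3 already stands at the limit of > 100000 nM in this assay, at which 1 of the 3 values shown sits, compound 4 is expected to be reported at the limit as well. The estimate for compound 4 is 200000 nM, with a range from 100000 nM to 500000 nM.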

Compound 4, half-maximal inhibitory concentration: > 100000 nM
Compound 4 ended at the assay's limit (the forecaster's own chance of this, stated with the estimate: 85%); the middle value is on the limit's open side.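

Compound 3 and compound 4 both stand at a limit of this assay and not at a number, so no step can be read between them: the limit of > 100000 nM in this assay, at which 2 of the 4 values shown sit.

The compounds shown leave open whether 4-(tert-butyl)phenyl in place of 3-methoxyphenyl changes inhibition on the core of compound 3 in the same direction and by the same size as on the core of compound 1.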